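This account rests on a few compounds, and the source may have more. Where it says the series, first, only, none or still open, it means among the compounds named here.

Measured in a functional assay on C6 cells (Rattus norvegicus) for cytotoxicity, read by MTT assay, with a stated time of 24 h, tested at 25 ug/mL; a higher number here means a weaker effect of the compound at the concentration tested, a lower number a stronger effect:
compound 1 `Cn1cnnc1SCC(=O)N/N=c1/scc(-c2ccc(C#N)cc2)n1-c1ccccc1` gives 58.8%;
compound 2 `O=C(CSc1nnnn1-c1ccccc1)N/N=c1/scc(-c2ccc(Cl)cc2)n1-c1ccccc1` gives 62.3%;
compound 3 `Cc1nnc(SCC(=O)N/N=c2/scc(-c3ccc(Cl)cc3)n2-c2ccccc2)s1` gives 53.3%.

Compound 2 has the highest number of the three, yet compound 1 and compound 3 both lie within the scatter of it. Within the data shown here, the only measured step, a number 9 percentage points lower from compound 2 to compound 3 (within the scatter), puts 5-methyl-1,3,4-thiadiazol-2-yl in place of 1-phenyl-1H-tetrazol-5-yl on a sulfur, a different change from the one at hand.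

Compound 4 `N#Cc1ccc(-c2cs/c(=N/NC(=O)CSc3nnnn3-c3ccccc3)n2-c2ccccc2)cc1` differs from compound 2 as follows: cyano in place of chloro on an aromatic carbon. Among the measured compounds shown here, compound 1 also carries cyano, but no single-point step links compound 1 to compound 2, and their values sit within the scatter. For the measured compounds named here, no measured step bears on this change, so in this assay nothing beyond the scatter is looked for. The expected step is a number 2.3 percentage points lower from compound 2 to compound 4 (within the scatter). Compound 4 is estimated at 60%, with a range of 48% to 72%.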

Compound 4, a percentage reported as activity, at one concentration (the size of the read-out at that concentration, not a potency): 64.2%
The estimate for compound 4 lay 4.2 percentage points below the measured number; the measured number falls inside the stated range.
By their numbers in this assay, from the lowest: compounds 3, 1, 2 and 4 (each within the scatter of the next, the first and the last beyond it).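

In this assay, among these compounds, cyano in place of chloro on this aromatic carbon gives the first direct reading of the change (a number 1.9 percentage points higher from compound 2 to compound 4 (within the scatter)). With 4-cyanophenyl held fixed, 1-phenyl-1H-tetrazol-5-yl in place of 4-methyl-4H-1,2,4-triazol-3-yl on the sulfur also stays within the scatter (a number 5.4 percentage points higher from compound 1 to compound 4 (within the scatter)). Nothing at hand explains either step.

Going by these compounds, whether an amine, a carboxylic acid or a longer chain on this aromatic carbon would move the read-out beyond the scatter stays open. So does the effect of cyano alongside 5-methyl-1,3,4-thiadiazol-2-yl on the sulfur.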